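The source may hold more compounds than are shown below. What is called first, only, known or untested is meant among the compounds shown, and "the series" means these compounds.

Measured compounds, each with its result in a functional assay on HT-22 cells (Mus musculus), read by MTT assay, with a stated time of 24 h; on this read-out lower numbers stand for an effect already at smaller amounts and higher numbers for an effect only at larger amounts of compound:

- compound 1, `COc1cc(-c2ccc(O)cc2)nc2ccccc12`, gives "not active" (no number reported)
- compound 2, `COc1cc(-c2cc(=O)c3cc(C)c(C)cc3o2)ccc1OCc1ccccc1`, gives 500 nM
- compound 3, `COc1cc(-c2oc3cc(C)c(C)cc3c(=O)c2O)ccc1OCc1ccccc1`, gives 170 nM

The three compounds fall into two groups. Compound 2 and compound 3 share one core, and compound 1 has another; the difference between the two cores is not broken down here. For compound 1 the result in this assay is reported only as inactive, without a number.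

Within the first core, the change from compound 2 to compound 3 is hydroxy in place of hydrogen on an aromatic carbon. It gave a 2.9-fold lower number from compound 2 to compound 3 (0.47 log units; beyond the scatter).

The unmeasured compound 4, `COc1cc(-c2ccc(O)cc2O)nc2ccccc12`, stands to compound 1 as compound 3 stands to compound 2: the change is hydroxy in place of hydrogen on an aromatic carbon. It is the same kind of change, not the same. In compound 1 the hydroxy enters a six-membered aromatic ring of carbon only, ortho to a large group and meta to a hydroxy group, whereas in compound 2 it enters a six-membered aromatic ring with one oxygen that is part of a fused system, ortho to a group of one heavy atom, two atoms from the ring oxygen, meta and para to a fused ring.

The step in the first core was modest, and compound 1 gives no number from which a step could be taken. Compound 4 is therefore expected to remain weak in this assay, with an estimate of 30000 nM, between 3000 nM and 300000 nM, and a real chance that again only inactivity is reported.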

Compound 4, half-maximal effective concentration: > 500 nM
Compound 4 ended at the assay's limit; the forecaster's own chance of this, stated with the estimate: 60%; the middle value does not contradict the limit.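

In this assay compound 4 gives > 500 nM, which is a limit of the assay and not a number. Going by these compounds alone, compound 1 has no number either, so no step from compound 1 to compound 4 can be read. The compounds shown leave open whether hydroxy in place of hydrogen on an aromatic carbon changes the result at all in the core of compound 1.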